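Trimethoxyphenyl in place of methylphenyl on a reversed enone

The source may report more compounds than this note shows. Statements on the series, on what has been measured and on what is new or still open speak of the compounds shown alone.

Three members of this series have been measured in a functional assay on A549 cells (Homo sapiens) for antiproliferative activity, read by MTT assay, with a stated time of 24 h; a higher number here means a weaker inhibitor, a lower number a stronger inhibitor. Compound 1 `COc1ccc(-c2cc(/C=C/C(=O)c3cc(OC)c(OC)c(OC)c3)nc3cc(-c4ccccc4)nn23)cc1OC` gives 7200 nM. Compound 2 `COc1ccc(-c2cc(/C=C/C(=O)c3ccc(C)cc3)nc3cc(-c4ccccc4)nn23)cc1OC` gives 17200 nM. Compound 3 `COc1cc(-c2cc(C(=O)/C=C/c3ccc(C)cc3)nc3cc(-c4ccccc4)nn23)cc(OC)c1OC` gives 20000 nM; compound 3 carries the highest number of the three, though its gap to compound 2 lies within the scatter, while its gap to compound 1 lies beyond it. How the core of compound 2 differs from the core of compound 3 is not broken down here.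

One structural change appears twice among these compounds. From compound 2 to compound 1 the change is 3,4,5-trimethoxyphenyl in place of 4-methylphenyl on a carbonyl carbon, and it brought a 2.4-fold lower number from compound 2 to compound 1 (0.38 log units; beyond the scatter), a modest step. Compound 4 `COc1cc(/C=C/C(=O)c2cc(-c3cc(OC)c(OC)c(OC)c3)n3nc(-c4ccccc4)cc3n2)cc(OC)c1OC` has not yet been measured; it differs from compound 3 by 3,4,5-trimethoxyphenyl in place of 4-methylphenyl on a double-bonded chain carbon bound to a double-bonded chain carbon. The two places are not the same: in the first case the new group sits on a carbonyl carbon whose other neighbour is a double-bonded chain carbon, in the second on a double-bonded chain carbon bound to a double-bonded chain carbon. The two are therefore the same kind of change, not the same change.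

Within the data shown here, the step is estimated at a 2.2-fold lower number from compound 3 to compound 4 (0.35 log units; beyond the scatter) in this assay, close in size to the earlier one, resting on the single measured precedent in compound 2 and compound 1 and allowing for the shifted place. Compound 4 is expected near 9000 nM, between 4000 nM and 25000 nM.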

Compound 4, half-maximal inhibitory concentration: 25900 nM
Compound 4: the middle estimate sits 2.9-fold (0.46 log units) below what was measured, outside the stated range (above it).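

In this assay, 3,4,5-trimethoxyphenyl in place of 4-methylphenyl on a double-bonded chain carbon bound to a double-bonded chain carbon gave a 1.3-fold higher number from compound 3 to compound 4 (0.11 log units; within the scatter), so the lower number seen with the earlier pair did not recur. The change therefore did not carry from one core to the other as a step of fixed size, and the difference between the two steps is larger than repeated measurements would be expected to produce: the same change on two cores in this assay, a 2.4-fold lower number (0.38 log units; beyond the scatter) from compound 2 to compound 1 and a 1.3-fold higher number (0.11 log units; within the scatter) from compound 3 to compound 4, 3.1-fold (0.49 log units) apart, beyond the scatter of two such steps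

Among these compounds, this shows that, in these four compounds, the same kind of change at two different places need not give the same result, but with only one pair on each side it does not show whether the place of the new group, the rest of the core or both lie behind the gap, and it supports no general rule for the series.

The compounds shown leave open how the change would behave if it stood at the same place on both cores. They also leave open whether an amine or a carboxylic acid in place of the 3,4,5-trimethoxyphenyl would shift the number in this assay on either core.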